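The source may hold more compounds than are shown below. What is called first, only, known or untested is meant among the compounds shown, and "the series" means these compounds.

Measured so far, in a functional assay on NCI-H322M cells (Homo sapiens) for cytotoxicity, read by sulforhodamine B assay, with a stated time of 48 h, tested at 0.1 uM; on this read-out higher numbers stand for a weaker effect at the one concentration tested and lower numbers for a stronger effect:
- compound 1, `COc1cc(-c2cc(/C=C/C(=O)c3ccc(Cl)c(Cl)c3)[nH]n2)cc(OC)c1OC`, gives 92%
- compound 2, `COc1ccc(-c2cc(/C=C/C(=O)c3cc(OC)c(OC)c(OC)c3)[nH]n2)cc1OC`, gives 88%
- compound 3, `COc1ccc(C(=O)/C=C/c2cc(-c3cc(OC)c(OC)c(OC)c3)n[nH]2)cc1OC`, gives 101%

Compound 3 has the highest of the three numbers; compound 1 lies nearest to it, and the gap to compound 2 is beyond the scatter. Compound 4, `COc1cc(C(=O)/C=C/c2cc(-c3cc(OC)c(OC)c(OC)c3)n[nH]2)cc(OC)c1OC`, is not yet measured. It differs from compound 3 in one place: methoxy in place of hydrogen on an aromatic carbon.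

Among the compounds with values here, only one measured step bears on it, and only loosely. The step of a number 9 percentage points higher from compound 1 to compound 3 (within the scatter) exchanged the whole aryl group on the carbonyl carbon and still stayed within the scatter. Within the data shown here, no measured pair shows the addition of a single methoxy group on that aryl group. Given that a larger change at the same part of the molecule moved the read-out so little, a step of about a number 5 percentage points lower from compound 3 to compound 4 (within the scatter) is expected, meaning no change beyond the scatter. Compound 4 is therefore estimated at 96% in this assay, with a range from 82% to 108%.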

Compound 4, a percentage reported as activity, at one concentration (the size of the read-out at that concentration, not a potency): 97%
The estimate for compound 4 lay 1 percentage points below the measured number; the range from low to high includes it.
By their numbers in this assay, from the lowest: compounds 2, 1, 4 and 3 (each within the scatter of the next, the first and the last beyond it).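

The first single methoxy addition on the aryl group at the carbonyl carbon gives a number 4 percentage points lower from compound 3 to compound 4 (within the scatter) in this assay, so this position tolerates the extra methoxy without a change beyond the scatter. The same replacement of hydrogen by methoxy on the other aryl group gives a number 9 percentage points higher from compound 2 to compound 4 (within the scatter), so in these two pairs neither placement moves the read-out beyond the scatter. Nothing available explains this outcome.

The compounds shown leave open whether an amine, a carboxylic acid or a longer alkoxy chain at this position would shift the read-out beyond the scatter. They also leave open how these compounds would behave at other concentrations, since each was read at only one, and that single reading gives no potency.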